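The compounds below may be only part of what the source reports. "The series", "measured", "known", "first", "only" and "open" are said of these compounds alone.

Measured so far:
compound 1 `COc1cccc(Oc2ccc3c(NCCCNCc4cc(F)ccc4OC)ccnc3c2)c1`: 14500 nM
compound 2 `COc1cccc(CNCCCNc2ccnc3cc(Cc4ccccc4)ccc23)c1O`: 4200 nM
compound 3 `COc1ccc(F)cc1CNCCCNc1ccnc2cc(-c3ccc(F)cc3)ccc12`: 32000 nM

In a physicochemical assay for solubility, with a stated time of 18 h, at pH 7.4 (a higher number here means a more soluble compound, a lower number a less soluble compound), compound 3 stands highest of the three numbers; compound 1 is nearest, compound 2 furthest. Compound 4 `COc1ccc(F)cc1CNCCCNc1ccnc2cc(Cc3ccccc3)ccc12` differs from compound 3 by benzyl in place of 4-fluorophenyl on an aromatic carbon. Among the compounds with values here, the one measured step at this aromatic carbon is a 2.2-fold higher number from compound 1 to compound 3 (0.34 log units; beyond the scatter), a modest rise, though with a different group leaving. Compound 2 carries a benzyl at the same carbon but a different side chain, so it gives only a loose pointer; its number sits well under that of compound 3. A downward step is therefore expected, estimated as a 2.1-fold lower number from compound 3 to compound 4 (0.33 log units; beyond the scatter). Compound 4 is expected near 15000 nM, within a range of 5000 nM to 45000 nM.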

Compound 4, solubility: 4200 nM
Beside the measured number, compound 4's estimate is 3.6-fold (0.55 log units) above it, and the stated range ends above it.
By their numbers in this assay, from the lowest: compounds 2 and 4 (each within the scatter of the next); then compound 1; then compound 3.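

In this assay the aromatic carbon is sensitive to the group it carries: benzyl in place of 4-fluorophenyl gives a 7.6-fold lower number from compound 3 to compound 4 (0.88 log units; beyond the scatter) and benzyl in place of 3-methoxyphenoxy gives a 3.5-fold lower number from compound 1 to compound 4 (0.54 log units; beyond the scatter) on the same side chain. Among these three groups, benzyl therefore gives the lowest number. With benzyl on the core, exchanging the side-chain aryl group gives no change at the digits printed from compound 2 to compound 4 (within the scatter) so 5-fluoro-2-methoxyphenyl and 2-hydroxy-3-methoxyphenyl do not separate here.

Open, from the compounds shown here alone, is how plain phenyl or a benzyl carrying an amine would read at this carbon. Nothing at hand accounts for these steps.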